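This account rests on a few compounds, and the source may have more. Where it says the series, first, only, none or still open, it means among the compounds named here.

In a functional assay on COLO 205 cells (Homo sapiens) for cytotoxicity, read by sulforhodamine B assay, with a stated time of 48 h (a lower number here means a stronger inhibitor, a higher number a weaker inhibitor), compound 1 (`COc1cc(/C=C/C(=O)/C=C/c2cccc3ccccc23)ccc1OCc1cn(CCCOc2cc(=O)oc3ccccc23)nn1`) gives 12700 nM. Compound 2 (`COc1ccc(/C=C/C(=O)/C=C/c2ccc(OCc3cn(CCOc4cc(=O)oc5ccccc45)nn3)c(OC)c2)cc1OC`) gives 6780 nM, and compound 3 (`COc1cc(/C=C/C(=O)/C=C/c2ccco2)ccc1OCc1cn(CCOc2cc(=O)oc3ccccc23)nn1`) gives 11800 nM. All three values lie within the scatter of one another, so compound 1 cannot be separated from the other two. Compound 4 (`COc1cc(/C=C/C(=O)/C=C/c2cc(OC)c(OC)c(OC)c2)ccc1OCc1cn(CCCOc2cc(=O)oc3ccccc23)nn1`) differs from compound 1 in one place: 3,4,5-trimethoxyphenyl in place of naphthalen-1-yl on a double-bonded chain carbon bound to a double-bonded chain carbon. Within the data shown here, the only measured change at that place is a 1.7-fold higher number from compound 2 to compound 3 (0.24 log units; within the scatter), so no step beyond the scatter is expected here. The estimated step is a 1.3-fold lower number from compound 1 to compound 4 (0.13 log units; within the scatter). For compound 4 the expected value is 9500 nM, with an estimated range of 4500 nM to 19000 nM.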

Compound 4, half-maximal inhibitory concentration: 10600 nM
Estimate against measurement, compound 4: 1.1-fold (0.05 log units) below; the range from low to high includes it.
By their numbers in this assay, from the lowest: compounds 2, 4, 3 and 1 (each within the scatter of the next).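

In this assay, 3,4,5-trimethoxyphenyl in place of naphthalen-1-yl gives a 1.2-fold lower number from compound 1 to compound 4 (0.08 log units; within the scatter), so a second change on a double-bonded chain carbon bound to a double-bonded chain carbon also stays within the scatter. Unlike the step between compound 2 and compound 3, this one replaces two six-membered aromatic rings with one that carries 3 hydrogen-bond acceptors, and the number still does not move beyond the scatter. No evidence is available that bears on this result. On these data alone, whether an amine or a carboxylic acid at this place would give a step beyond the scatter remains open.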